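A Chlorine Added to the Thiophene Hydrazone

The source may hold more compounds than are shown below. What is called first, only, known or untested is meant among the compounds shown, and "the series" means these compounds.

Compound 1, `Clc1ccc(/C=N/N(Cc2ccccc2)Cc2ccccc2)cc1`, gives 240 nM in an assay on liver (Sus scrofa) for inhibition of glucose-6-phosphatase catalytic subunit 1 (Homo sapiens), using microsomes; a lower number here means a stronger inhibitor, a higher number a weaker inhibitor.
Compound 2, `C(=N/N(Cc1ccccc1)Cc1ccccc1)\c1cccs1`, gives 1500 nM in this assay.

Of the compounds shown here, two have been measured so far, and they share the same core: a hydrazone carrying two benzyl groups on nitrogen, with an aromatic ring on the carbon that is doubly bonded to nitrogen. For the measured compounds named here, the only measured step between them, a 6.3-fold higher number from compound 1 to compound 2 (0.80 log units; beyond the scatter), shows that compound 2 is the weaker inhibitor of the two, standing highest of the two numbers.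

Compound 3, `Clc1ccc(/C=N/N(Cc2ccccc2)Cc2ccccc2)s1`, keeps the thiophene of compound 2 and differs from it by chloro in place of hydrogen on an aromatic carbon. Going by the values given here, no measured step adds a chloro atom to an otherwise unchanged ring, so the size of this change cannot be read from the data. The step from compound 1 to compound 2 exchanges the whole aromatic ring and therefore does not bear directly on it. The expectation is accordingly a small step, or none beyond the scatter, in this assay, with a slight lean towards a lower number, giving a 1.5-fold lower number from compound 2 to compound 3 (0.18 log units; within the scatter). Compound 3 is estimated at 1000 nM, in a range from 300 nM to 3000 nM.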

Compound 3, half-maximal inhibitory concentration: 170 nM
Estimate against measurement, compound 3: 5.9-fold (0.77 log units) above; the whole stated range lies above it.
By their numbers in this assay, from the lowest: compounds 3 and 1 (each within the scatter of the next); then compound 2.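

In this assay, a single chloro on the thiophene, on the aromatic carbon next to the ring sulfur, produces a step beyond the scatter: an 8.8-fold lower number from compound 2 to compound 3 (0.95 log units; beyond the scatter). This shows that the position is sensitive to replacing hydrogen with chloro, something the earlier whole-ring exchange could not reveal. With chloro on both rings, 5-chlorothiophen-2-yl and 4-chlorophenyl cannot be told apart, as the change lies within the scatter: a 1.4-fold lower number from compound 1 to compound 3 (0.15 log units; within the scatter); among these three compounds, the high number therefore goes with the ring lacking chloro, not with thiophene as such. Nothing shown here explains why chloro has this effect.

Going by these compounds, it remains open whether the same position would respond similarly to other groups, such as methyl, bromo, an amine or a carboxylic acid, or whether chloro is special there. A plain phenyl ring without chloro is also absent from the compounds shown, so it cannot yet be said whether chloro on the six-membered ring matters as much as it does on the thiophene.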